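The compounds below may be only part of what the source reports. "The series", "measured", "known", "first", "only" and "open" are said of these compounds alone.

Compound 1 `O=S(=O)(Nc1ccc(-c2nc3ccccc3o2)cc1)c1cccc(Cl)c1` and compound 2 `CS(=O)(=O)Nc1ccc(-c2nc3ccccc3o2)cc1` share one core and differ only in the group on the sulfonyl sulfur. In an assay on isolated protein for inhibition of malate dehydrogenase, mitochondrial (Sus scrofa), with stated times of 45 min and 30 min (a lower number here means a stronger inhibitor, a higher number a weaker inhibitor), compound 1 reaches only the limit of > 63000 nM. In this assay compound 2 likewise reaches only the limit of > 63000 nM. The step that the two limits leave unreadable from compound 1 to compound 2 therefore cannot be read, as the limit of > 63000 nM in this assay, at which 2 of the 2 values shown sit, shows. Compound 3 `O=S(=O)(Nc1ccc(-c2nc3ccccc3o2)cc1)c1cccs1` carries the change (thiophen-2-yl in place of methyl on a sulfonyl sulfur). With both measured values sitting at a limit, no readable difference is expected for compound 3 either. Compound 3 is estimated at 100000 nM, between 30000 nM and 300000 nM. The expected step that the limit leaves unreadable from compound 2 to compound 3 is no change beyond the scatter.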

Compound 3, half-maximal inhibitory concentration: > 63000 nM
Compound 3 ended at the assay's limit; the forecaster's own chance of this, stated with the estimate: 80%; the middle value does not contradict the limit.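

Within the data shown here, no step among compound 1, compound 2 and compound 3 can be read, as each result is a limit and not a number: the limit of > 63000 nM in this assay, at which 3 of the 3 values shown sit. As far as these compounds go, whether methyl, 3-chlorophenyl and thiophen-2-yl on the sulfonyl sulfur differ at all remains open.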